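A few compounds are considered here, and "the series" means these few. Any claim that something is new, unique, unknown or untested is made for them only; others in the source may bear on it.

Measured in a functional assay on HepG2 cells (Homo sapiens) for cytotoxicity, read by sulforhodamine B assay, with a stated time of 48 h; a lower number here means a stronger inhibitor, a higher number a weaker inhibitor:

- compound 1 `N#Cc1c(-c2ccc(Cl)cc2)cc(-c2ccc(Cl)cc2)n([C@@H]2O[C@H](COC(=O)c3ccccc3)[C@@H](OC(=O)c3ccccc3)[C@H]2OC(=O)c2ccccc2)c1=O`: 8 ug/mL
- compound 2 `N#Cc1c(-c2ccc(Cl)cc2)cc(-c2ccc(Cl)cc2)n(CC2CO2)c1=O`: 6.2 ug/mL
- compound 3 `CC(=O)OC[C@H]1O[C@@H](n2c(-c3ccc(Cl)cc3)cc(-c3ccc(Cl)cc3)c(C#N)c2=O)[C@H](OC(C)=O)[C@@H](OC(C)=O)[C@@H]1OC(C)=O`: 7.25 ug/mL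

Compound 2 stands at 6.2 ug/mL in this assay, and this number lies within the scatter of those of compound 3 and compound 1, so the three cannot be ranked. The next compound to be tested is compound 4 `CCn1c(-c2ccc(Cl)cc2)cc(-c2ccc(Cl)cc2)c(C#N)c1=O`, which carries methyl in place of oxiran-2-yl on a saturated chain carbon bound to an aromatic nitrogen.

Among the compounds with values here, no pair of measured compounds differs in only one place, so no single change has a measured effect to draw on. The three compounds do differ in what is bound to the aromatic nitrogen, yet compound 1 at 8 ug/mL and compound 3 at 7.25 ug/mL remain within the scatter of compound 2 at 6.2 ug/mL. On that basis, no change beyond the scatter is expected in this assay. The estimated step of a 1.1-fold higher number from compound 2 to compound 4 (0.05 log units; within the scatter) is therefore small, and its direction is not secure. For compound 4 the expected value is 7 ug/mL, with an estimated range from 3.5 ug/mL to 14 ug/mL.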

Compound 4, half-maximal inhibitory concentration: 22.3 ug/mL
Compound 4: the middle estimate sits 3.2-fold (0.50 log units) below what was measured; the whole stated range lies below it.
By their numbers in this assay, from the lowest: compounds 2, 3 and 1 (each within the scatter of the next); then compound 4.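

In this assay, the group on the saturated chain carbon bound to the aromatic nitrogen proves to matter: methyl in place of oxiran-2-yl gives a 3.6-fold higher number from compound 2 to compound 4 (0.56 log units; beyond the scatter), a modest step that lies beyond the scatter. Within the data shown here, this is the first change in a single place with a measured effect, which the earlier compounds could not provide, as no two of them differed in only one place. Nothing available accounts for this step.

The compounds shown leave open whether the step follows from the loss of the three-membered ring, of its oxygen or of the additional heavy atoms. A cyclopropyl group or a hydroxymethyl group in the place of oxiran-2-yl, or a longer alkyl chain on the aromatic nitrogen, would help to separate these possibilities.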